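Notes on a chloro addition across two cores

The source may report more compounds than this note shows. Statements on the series, on what has been measured and on what is new or still open speak of the compounds shown alone.

Measured compounds:
compound 1 `Fc1cc(Cl)ccc1-c1ccc(Cn2nnc3ccccc32)cn1`: 50 nM
compound 2 `Fc1ccccc1-c1ccc(Cn2nnc3ccccc32)cn1`: 600 nM
compound 3 `Fc1ccc(Cn2nnc3c(Br)cccc32)cc1`: 15 nM

All numbers come from a functional assay on cells for positive allosteric modulation of metabotropic glutamate receptor 2 (Homo sapiens), read by fluorescence and calcium flux, with a stated time of 30 min; on this read-out lower numbers stand for an effect already at smaller amounts and higher numbers for an effect only at larger amounts of compound. Compound 1 and compound 2 share a core and differ by chloro in place of hydrogen on an aromatic carbon; the step is a 12-fold lower number from compound 2 to compound 1 (1.08 log units; beyond the scatter). Compound 3 sits on a different core; the difference between the two cores is not broken down here. Compound 3 gives the lowest number of the three.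

Compound 4 `Fc1ccc(Cn2nnc3c(Br)cccc32)c(Cl)c1` is not yet measured; it differs from compound 3 by chloro in place of hydrogen on an aromatic carbon. This is the same kind of change as the one measured earlier, but the surroundings differ: earlier the chloro sat meta to a fluoro group and para to a large group, here it sits ortho to a large group and meta to a fluoro group. Because the earlier step of a 12-fold lower number from compound 2 to compound 1 (1.08 log units; beyond the scatter) was measured on another core and at a different place, a smaller step in the same direction is expected for compound 4: a 2.1-fold lower number from compound 3 to compound 4 (0.33 log units; beyond the scatter). Compound 4 is estimated at 7 nM, within 2 nM to 30 nM.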

Compound 4, half-maximal effective concentration: 190 nM
Beside the measured number, compound 4's estimate is 27-fold (1.43 log units) below it; measured number above the stated range.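

In this assay, chloro in place of hydrogen on an aromatic carbon, here ortho to a large group and meta to a fluoro group, gives a 13-fold higher number from compound 3 to compound 4 (1.10 log units; beyond the scatter). The same change does not carry over from one core to the other in this series, as the two steps run in opposite directions: the same change on two cores in this assay, a 12-fold lower number (1.08 log units; beyond the scatter) from compound 2 to compound 1 and a 13-fold higher number (1.10 log units; beyond the scatter) from compound 3 to compound 4, 150-fold (2.18 log units) apart, beyond the scatter of two such steps. Whether the core or the place of the chloro decides the difference is not shown, as the two pairs differ in both.

Open, on these data alone, is whether a methyl group or an amine at the same place on compound 3 would follow chloro. Also open, as far as these compounds go, is whether chloro elsewhere on that ring of compound 3 would lower the number.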